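Swapping the phenyl for a 3-chloro-4-fluorophenyl

The compounds below may be only part of what the source reports. "The series", "measured", "known", "first", "only" and "open" are said of these compounds alone.

The study measures two compounds in a functional assay on A549 cells (Homo sapiens) for inhibition, read by MTT assay, with a stated time of 72 h; on this read-out higher numbers stand for weaker inhibition and lower numbers for stronger inhibition. Compound 1, `O=C(Nc1ccc(Oc2ccnc3[nH]ccc23)cc1)c1cn(-c2ccc(F)c(Cl)c2)c2ccccc2c1=O`, gives 4810 nM in this assay. Compound 2, `Cn1ccc2c(Oc3ccc(NC(=O)c4cn(-c5ccccc5)c5ccccc5c4=O)cc3F)ccnc21`, gives 1720 nM in this assay, the lower of the two numbers; the gap to compound 1 lies beyond the usual scatter. Compound 1 and compound 2 differ at more than one place, so their two values say nothing about any single change.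

Compound 3, `Cn1ccc2c(Oc3ccc(NC(=O)c4cn(-c5ccc(F)c(Cl)c5)c5ccccc5c4=O)cc3F)ccnc21`, has not been measured. It differs from compound 2 in one place: 3-chloro-4-fluorophenyl in place of phenyl on an aromatic nitrogen. Going by the values given here, compound 1 also carries a 3-chloro-4-fluorophenyl on the same aromatic nitrogen, yet it differs from compound 3 elsewhere too, so no measured pair isolates this change. The estimate for compound 3 therefore stays close to compound 2, with the step of a 1.3-fold higher number from compound 2 to compound 3 (0.11 log units; within the scatter) expected to fall within the usual scatter, and the range is kept wide. Compound 3 is expected to give about 2200 nM in this assay, between 900 nM and 5500 nM.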

Compound 3, half-maximal inhibitory concentration: 1210 nM
Compound 3: middle estimate off by 1.8-fold (0.26 log units), on the high side, within the range that was stated.
By their numbers in this assay, from the lowest: compounds 3 and 2 (each within the scatter of the next); then compound 1.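

In this assay, the place on the aromatic nitrogen now has a clean pair, since 3-chloro-4-fluorophenyl in place of phenyl is a 1.4-fold lower number from compound 2 to compound 3 (0.15 log units; within the scatter) and no other part of the structure changes. Compounds 1 and 2 could not show this, as they differ at more than one place, whereas here the two compounds cannot be told apart on this read-out, so on the core of compound 2 this position carries the larger 3-chloro-4-fluorophenyl group, with its chlorine and fluorine, without a change beyond the scatter. Nothing measured here bears on why the read-out stays within the scatter across this change.

As far as these compounds go, the chlorine and the fluorine are seen only together, so what a 3-chlorophenyl or a 4-fluorophenyl alone would give at this nitrogen stays open. Also open, from the compounds shown here alone, is how this position would respond to something other than a halogen-bearing phenyl, such as a phenyl carrying an amine or a carboxylic acid, or a longer alkyl chain in place of the ring.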